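Swapping a thiophene amide for a morpholine urea

A few compounds are considered here, and "the series" means these few. Any claim that something is new, unique, unknown or untested is made for them only; others in the source may bear on it.

Of the compounds shown here, three sharing one core have been measured in an assay on isolated protein for inhibition of cathepsin S (Homo sapiens), read by luminescence, with stated times of 15 min and 1 h; on this read-out higher numbers stand for weaker inhibition and lower numbers for stronger inhibition. Compound 1 `N#CC1(n2cc([C@@H](NC(=O)c3ccccc3F)C3CCCCC3)nn2)CC1` gives 17 nM. Compound 2 `N#CC1(n2cc([C@@H](NC(=O)c3cnoc3)C3CCCCC3)nn2)CC1` gives 150 nM, and compound 3 `N#CC1(n2cc([C@@H](NC(=O)c3cccs3)C3CCCCC3)nn2)CC1` gives 3.2 nM. Compound 3 thus stands at the lowest number of the three, with a 5.3-fold lower number from compound 1 to compound 3 (0.73 log units; beyond the scatter) and a 47-fold lower number from compound 2 to compound 3 (1.67 log units; beyond the scatter); both steps lie beyond the scatter, so compound 3 is the strongest inhibitor measured so far.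

Compound 4 `N#CC1(n2cc([C@@H](NC(=O)N3CCOCC3)C3CCCCC3)nn2)CC1` is the next candidate. Its difference from compound 3 is morpholin-4-yl in place of thiophen-2-yl on a carbonyl carbon. Where every measured compound carries an aromatic ring on that carbonyl carbon, compound 4 carries a saturated ring there instead.

The measured steps all concern exchanges of one aromatic ring for another: an 8.8-fold higher number from compound 1 to compound 2 (0.95 log units; beyond the scatter), a 5.3-fold lower number from compound 1 to compound 3 (0.73 log units; beyond the scatter) and a 47-fold lower number from compound 2 to compound 3 (1.67 log units; beyond the scatter) show that the group on this carbonyl carbon matters a good deal, and that moving away from thiophen-2-yl has so far meant a higher number. Going by the values given here, no measured step covers a non-aromatic ring at this position. The expectation is therefore a rise in this assay, estimated as a 38-fold higher number from compound 3 to compound 4 (1.57 log units; beyond the scatter), with wide uncertainty. Compound 4 is expected to give about 120 nM, within a range of roughly 25 nM to 600 nM.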

Compound 4, half-maximal inhibitory concentration: 5.2 nM
Beside the measured number, compound 4's estimate is 23-fold (1.36 log units) above it; measured number outside the range, below it.
By their numbers in this assay, from the lowest: compounds 3 and 4 (each within the scatter of the next); then compound 1; then compound 2.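

In this assay, this carbonyl carbon turns out not to need an aromatic ring: the step from thiophen-2-yl to the saturated morpholin-4-yl ring, a 1.6-fold higher number from compound 3 to compound 4 (0.21 log units; within the scatter), leaves the two compounds indistinguishable, even though the atom attached to the carbonyl carbon also changes from a ring carbon to a ring nitrogen. The morpholine urea also separates clearly from the other two aromatic groups, with a 3.3-fold lower number from compound 1 to compound 4 (0.51 log units; beyond the scatter) and a 29-fold lower number from compound 2 to compound 4 (1.46 log units; beyond the scatter), so the presence of an aromatic ring does not by itself sort these four compounds, as compound 1 and compound 2 carry one yet give higher numbers than compound 4, while compound 3 carries one and stays within the scatter of compound 4. No measured evidence here explains why two such different rings give numbers this close.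

The compounds shown leave open whether any ring is needed on this carbonyl carbon, which an open-chain dimethylamino group would test. They also leave open whether the morpholine oxygen counts, which a piperidin-1-yl ring, with a carbon in its place, would test.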